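Adding acetyl to the amino group of compound 2

The source may report more compounds than this note shows. Statements on the series, on what has been measured and on what is new or still open speak of the compounds shown alone.

Compound 1 `CCCc1ccc(C(=O)Nc2ccccc2-c2nnn(-c3cccc(OC)c3)n2)cc1`: 27000 nM
Compound 2 `COc1cccc(-n2nnc(-c3ccccc3NC(=O)c3ccc(N)cc3)n2)c1`: > 100000 nM

Both results come from an ADME assay on NCI-H460 cells (Homo sapiens) for cytotoxicity, read by MTT assay, with a stated time of 72 h; on this read-out lower numbers stand for stronger inhibition and higher numbers for weaker inhibition. Compound 2 sits at the limit of > 100000 nM in this assay, at which 1 of the 2 values shown sits. Its value of > 100000 nM is a limit of the assay and not a number, so compound 2 has no exact position on the scale.

The next compound, compound 3 `COc1cccc(-n2nnc(-c3ccccc3NC(=O)c3ccc(NC(C)=O)cc3)n2)c1`, has acetyl in place of hydrogen on a nitrogen on an aromatic ring. This turns amino into acetamido.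

For the measured compounds named here, only one measured step bears on this change. It is an at least 3.7-fold higher number from compound 1 to compound 2 (0.56 log units; beyond the scatter), and it comes from amino in place of propyl on an aromatic carbon. This single step shows that a change at this part of the molecule can move the result beyond the scatter, but it does not show what acetyl will do. A modest move towards a lower number is therefore expected, although compound 3 may well stay at the limit.

The expected change is an at least 1.4-fold lower number from compound 2 to compound 3 (0.15 log units; that floor lies within the scatter). For compound 3 the estimate in this assay is 70000 nM, with an expected range of 25000 nM to 150000 nM.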

Compound 3, half-maximal inhibitory concentration: > 100000 nM
Compound 3 ended at the assay's limit; the forecaster's own chance of this, stated with the estimate: 45%; middle value at least 1.4-fold (0.15 log units) away from the limit.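

In this assay compound 3 gives > 100000 nM, which is a limit of the assay and not a number, so acetyl on the nitrogen of the amino group does not bring the result to a readable value: the limit of > 100000 nM in this assay, at which 2 of the 3 values shown sit.

The step from amino to acetamido has a limit at both ends and cannot be read, so it cannot be said whether acetyl changes the result at all. What can be read is the comparison with propyl on the same aromatic carbon, where acetamido in place of propyl gives an at least 3.7-fold higher number from compound 1 to compound 3 (0.56 log units; beyond the scatter), the same floor that amino gave, which leaves the propyl compound as the only one of the three with an exact number.

On these data alone, how far beyond the limit compound 2 and compound 3 truly lie remains open, and so does the size of any gap between them. Also open, as far as these compounds go, is whether propyl stands out for its carbon chain, a question that a longer chain such as butyl, or a carboxylic acid at the same place, would help to answer.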